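This account rests on a few compounds, and the source may have more. Where it says the series, first, only, none or still open, it means among the compounds named here.

Measured compounds:
compound 1 `COc1ccc(CNC(=O)c2c(C)nc3cc(C)ccn23)cc1` gives 100% in a physicochemical assay for metabolic stability, read by LC-MS, in simulated gastric fluid, with a stated time of 15 min, tested at 50 uM; on this read-out higher numbers stand for a more stable compound and lower numbers for a less stable compound;
compound 2 `CC(C)(C)OC(=O)c1coc(-c2ccccc2)n1` has "not determined" (no result reported) in this assay;
compound 3 `Cc1cc(C)c(OC(=O)c2coc(-c3ccccc3)n2)c(C)c1` gives 1.4% in this assay.

For the measured compounds named here, compound 2 therefore stands nowhere on the numbers: its stability was not determined, so no step can be drawn from it. Compound 4 `O=C(Oc1ccccc1)c1coc(-c2ccccc2)n1` is the next member, and the change is phenyl in place of tert-butyl on an oxygen next to a carbonyl group. With no value for compound 2, neither size nor direction of the step in this assay can be stated. The only aryl ester with a number is compound 3, whose remaining fraction is 1.4%, far from the amide compound 1 at 100%. Compound 4 is expected to lie near compound 3, at about 5% (range 0% to 30%).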

Compound 4, percent of the compound remaining: 0.2%
For compound 4 the middle estimate is 4.8 percentage points above the measured one; measured number inside the range.
By their numbers in this assay, from the lowest: compounds 4 and 3 (each within the scatter of the next); then compound 1.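

No step can be read between compound 2 and compound 4. Nothing shown gives a cause for the result of compound 4. Left open is whether tert-butyl or phenyl on that oxygen gives the more stable compound.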